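Turning the Pyridine Around: From Compound 2 to Compound 4

The source may report more compounds than this note shows. Statements on the series, on what has been measured and on what is new or still open speak of the compounds shown alone.

Compound 1 `CC(C)(C)c1cc2n(n1)CCN(C(=O)c1ccc3ccccc3c1)C2`: 477 nM
Compound 2 `O=C(c1ccccc1)N1CCn2nc(-c3ccncc3)cc2C1`: 1290 nM
Compound 3 `O=C(c1ccc(Cl)cc1)N1CCn2nc(-c3ccccn3)cc2C1`: 9470 nM

In a functional assay on HEK293 cells for negative allosteric modulation of metabotropic glutamate receptor 5 (Homo sapiens), read by calcium flux, with a stated time of 20 min (on this read-out lower numbers stand for stronger inhibition and higher numbers for weaker inhibition), compound 2 gives 1290 nM, the second highest of the three numbers; compound 1 lies beyond the scatter below it, and compound 3 lies beyond the scatter above it. Compound 4 `Cc1ccc(-c2cc3n(n2)CCN(C(=O)c2ccccc2)C3)nc1` keeps the core and the benzoyl amide of compound 2 but changes the aromatic carbon substituent: 5-methylpyridin-2-yl in place of pyridin-4-yl on an aromatic carbon. Going by the values given here, no single-change step between measured compounds covers this swap; compound 3 carries a different pyridine but also a different amide, so it is only a loose hint. The expectation is a modest loss, a step beyond the scatter toward a higher number, a 2.3-fold higher number from compound 2 to compound 4 (0.37 log units; beyond the scatter). Compound 4 is therefore estimated at 3000 nM, within 1000 nM to 9000 nM.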

Compound 4, half-maximal inhibitory concentration: 244 nM
For compound 4 the middle estimate is 12-fold (1.09 log units) above the measured one; measured number outside the range, below it.
By their numbers in this assay, from the lowest: compounds 4 and 1 (each within the scatter of the next); then compound 2; then compound 3.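

In this assay, 5-methylpyridin-2-yl in place of pyridin-4-yl gives a 5.3-fold lower number from compound 2 to compound 4 (0.72 log units; beyond the scatter), with the core and the benzoyl amide unchanged. This shows that activity at this aromatic carbon depends on which substituted pyridine it carries, and that this swap is a gain rather than a loss. Nothing measured here explains the gain.

The swap alters both the pyridine attachment and the methyl, and these compounds cannot separate the two. From the compounds shown here alone, how a 5-chloropyridin-2-yl group would behave at this position also remains open.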